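From methylamino to methyl with thiophen-2-yl kept

The source may report more compounds than this note shows. Statements on the series, on what has been measured and on what is new or still open speak of the compounds shown alone.

Measured in a functional assay on K562 cells (Homo sapiens), read by MTT assay, with a stated time of 72 h; a lower number here means a stronger inhibitor, a higher number a weaker inhibitor:
- compound 1 `CSc1ncnc2c1c(-c1cccs1)cn2[C@@H]1O[C@H](CO)[C@@H](O)[C@H]1O`: 11600 nM
- compound 2 `CNc1ncnc2c1c(-c1ccco1)cn2[C@@H]1O[C@H](CO)[C@@H](O)[C@H]1O`: 220 nM
- compound 3 `CNc1ncnc2c1c(-c1cccs1)cn2[C@@H]1O[C@H](CO)[C@@H](O)[C@H]1O`: > 20000 nM

Compound 3 has no number, only a limit of the assay: > 20000 nM. Compound 4 `Cc1ncnc2c1c(-c1cccs1)cn2[C@@H]1O[C@H](CO)[C@@H](O)[C@H]1O` keeps the shared core and the thiophen-2-yl group, and carries methyl in place of methylamino on an aromatic carbon.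

Among the measured compounds shown here, two measured steps bear on this change, and neither replaces a group by methyl. The closer one exchanges a group at the same place: an at least 1.7-fold higher number from compound 1 to compound 3 (0.23 log units; that floor lies within the scatter). Its floor gives no firm difference between methylsulfanyl and methylamino. The other step is large, an at least 90-fold higher number from compound 2 to compound 3 (1.95 log units; beyond the scatter), but it concerns furan-2-yl and thiophen-2-yl, and that group does not change here.

A modest step toward a lower number is therefore expected in this assay, since compound 1 with the same thiophen-2-yl group gives 11600 nM. Another limit remains possible for compound 4. The expected step is an at least 3.3-fold lower number from compound 3 to compound 4 (0.52 log units; beyond the scatter). Compound 4 is estimated at 6000 nM, with an expected range from 800 nM to 20000 nM.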

Compound 4, half-maximal inhibitory concentration: > 20000 nM
Compound 4 was reported as a limit; the forecaster's own chance of this, stated with the estimate: 25%; middle value at least 3.3-fold (0.52 log units) away from the limit.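

In this assay compound 4 gives > 20000 nM, which is a limit and not a number, so with thiophen-2-yl kept, methyl on this aromatic carbon yields no measured value, just as methylamino does. The step between methylamino and methyl cannot be read, and the comparison with methylsulfanyl gives an at least 1.7-fold higher number from compound 1 to compound 4 (0.23 log units; that floor lies within the scatter), a floor that establishes no firm difference between methyl and methylsulfanyl. Removing methylamino, with its hydrogen-bond donor and acceptor, therefore brings no readable gain in this assay, and a second thiophen-2-yl compound now rests at the same limit: the limit of > 20000 nM in this assay, at which 2 of the 4 values shown sit.

The compounds shown leave open how far beyond the limit compound 3 and compound 4 lie. Nor do they show what methyl would give alongside furan-2-yl, the group carried by compound 2 at 220 nM. They also leave open whether a longer chain such as ethyl, or an amine such as dimethylamino, on this aromatic carbon would give a number in this assay with thiophen-2-yl kept.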